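This account rests on a few compounds, and the source may have more. Where it says the series, first, only, none or still open, it means among the compounds named here.

In a functional assay on K562 cells (Homo sapiens) for antiproliferative activity, read by MTT assay, with a stated time of 48 h (on this read-out lower numbers stand for stronger inhibition and higher numbers for weaker inhibition), compound 1 `CCN1C(=O)C(=O)c2cc(-c3ccc(OC)cc3)ccc21` gives 2200 nM and compound 2 `COc1ccc(-c2ccc3c(c2)C(=O)C(=O)N3Cc2ccc(Br)cc2)cc1` gives 100 nM, the lower of the two numbers. Among the compounds with values here, the only measured step, a 22-fold lower number from compound 1 to compound 2 (1.34 log units; beyond the scatter), comes from putting 4-bromophenyl in place of methyl on a saturated chain carbon bound to an amide-type nitrogen in a ring. Compound 3 `COc1ccc(-c2ccc3c(c2)C(=O)C(=O)N3Cc2ccccc2OC)cc1` is altered at that same place, with 2-methoxyphenyl in place of 4-bromophenyl on a saturated chain carbon bound to an amide-type nitrogen in a ring. That measured step bears on the change only in part, since it compares methyl with a phenyl group, and a phenyl group remains in compound 3. Within the data shown here, no measured pair compares two substituted phenyl groups. A much smaller change than that step is therefore expected in this assay, most likely towards a somewhat higher number. For compound 3 the estimated value is 250 nM, with an expected range of 60 nM to 1000 nM. This estimate amounts to an expected 2.5-fold higher number from compound 2 to compound 3 (0.40 log units; beyond the scatter).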

Compound 3, half-maximal inhibitory concentration: 40 nM
The estimate for compound 3 lay 6.3-fold (0.80 log units) above the measured number; measured number below the stated range.
By their numbers in this assay, from the lowest: compound 3; then compound 2; then compound 1.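

At this place, on a saturated chain carbon bound to an amide-type nitrogen in a ring, the earlier pair compared only methyl with 4-bromophenyl; compound 3 shows that the choice of substituted phenyl also shifts the number in this assay, with a 2.5-fold lower number from compound 2 to compound 3 (0.40 log units; beyond the scatter) for 4-bromobenzyl to 2-methoxybenzyl. Bromine is therefore not required for a number this low, and the step against methyl widens to a 55-fold lower number from compound 1 to compound 3 (1.74 log units; beyond the scatter). Nothing measured here accounts for either step.

The compounds shown leave open whether the gain follows the methoxy group itself or its place on the phenyl ring, a question that 4-methoxyphenyl and 2-bromophenyl at this same place would address. They also leave open how an unsubstituted phenyl or a phenyl carrying an amine or a carboxylic acid would compare.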